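Swapping a cyclopropylmethyl for a tert-butylbenzyl on the ring nitrogen

The source may report more compounds than this note shows. Statements on the series, on what has been measured and on what is new or still open speak of the compounds shown alone.

Measured compounds:
Compound 1, `COc1cc2c(=O)c(C(=O)c3ccc(C)cc3)cn(Cc3ccc(Cl)cc3)c2cc1OC`: 15500 nM
Compound 2, `COc1cc2c(=O)c(C(=O)c3ccc(C)cc3)cn(CC3CC3)c2cc1OC`: "not active" (no number reported)

In an ADME assay on Huh-7 cells (Homo sapiens) for cytotoxicity (on this read-out lower numbers stand for stronger inhibition of growth and higher numbers for weaker inhibition of growth), compound 2 is reported as "not active" (no number reported), so no number fixes where it stands. Compound 3, `COc1cc2c(=O)c(C(=O)c3ccc(C)cc3)cn(Cc3ccc(C(C)(C)C)cc3)c2cc1OC`, has not been tested. Its structure differs from compound 2 by 4-(tert-butyl)phenyl in place of cyclopropyl on a saturated chain carbon bound to an aromatic nitrogen. Going by the values given here, no measured pair shows the size of such a step in this assay, so the direction and size of the step rest on no data. Compound 1 gives 15500 nM in this assay. For compound 3 the expected value is 15000 nM, with a range from 4000 nM to 60000 nM, and a fair chance that only a limit is reported.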

Compound 3, concentration for 50% growth inhibition: > 25000 nM
Compound 3 gave a limit, no number (the forecaster's own chance of this, stated with the estimate: 40%); middle value at least 1.6-fold (0.22 log units) away from the limit.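

In this assay compound 3 gives > 25000 nM, which is a limit and not a number. Tert-butyl in place of chloro on an aromatic carbon brings an at least 1.6-fold higher number from compound 1 to compound 3 (0.20 log units; that floor lies within the scatter), so this read-out does not separate the two groups. The step between compound 2 and compound 3 cannot be read: neither has a number. Still open, as far as these compounds go, is whether an amine or a carboxylic acid in place of chloro, or a longer chain on the ring nitrogen, would give a clearly lower number than compound 1 at 15500 nM.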